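Amide series: trifluoromethyl in place of ethyl

This account rests on a few compounds, and the source may have more. Where it says the series, first, only, none or still open, it means among the compounds named here.

Three anilides sharing one core have been measured in an assay on CHO cells, read by calcium flux; on this read-out higher numbers stand for weaker inhibition and lower numbers for stronger inhibition. Compound 1 `CC(C)c1ccc(NC(=O)c2csc(Cc3c(Cl)cccc3Cl)n2)cc1` gives 520 nM; compound 2 `CCc1ccc(NC(=O)c2csc(Cc3c(Cl)cccc3Cl)n2)cc1` gives 1450 nM; compound 3 `CN(C)c1ccc(NC(=O)c2csc(Cc3c(Cl)cccc3Cl)n2)cc1` gives 1270 nM. Compound 2 holds the highest of the three numbers in this assay: its nearest neighbour is compound 3, with a 1.1-fold lower number from compound 2 to compound 3 (0.06 log units; within the scatter), and the furthest is compound 1, separated by a 2.8-fold higher number from compound 1 to compound 2 (0.45 log units; beyond the scatter).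

The next compound, compound 4 `O=C(Nc1ccc(C(F)(F)F)cc1)c1csc(Cc2c(Cl)cccc2Cl)n1`, differs from compound 2 in one place: trifluoromethyl in place of ethyl on an aromatic carbon. Among the measured compounds shown here, no measured step involves trifluoromethyl, so the only guidance is how this position has behaved under the other exchanges. There, a 2.8-fold higher number from compound 1 to compound 2 (0.45 log units; beyond the scatter) is modest, a 2.4-fold higher number from compound 1 to compound 3 (0.39 log units; beyond the scatter) is modest, and a 1.1-fold lower number from compound 2 to compound 3 (0.06 log units; within the scatter) lies within the scatter; every group tried so far has kept the number within a narrow band. Because compound 2 sits at the high end of that band with 1450 nM, a step toward a lower number, of modest size at most, is expected for compound 4 in this assay, and a step within the scatter cannot be excluded. The expected step is a 1.6-fold lower number from compound 2 to compound 4 (0.21 log units; within the scatter). The estimate for compound 4 in this assay is 900 nM, with a range from 300 nM to 2700 nM.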

Compound 4, half-maximal inhibitory concentration: 88 nM
Compound 4: middle estimate off by 10-fold (1.01 log units), on the high side, outside the stated range (below it).
By their numbers in this assay, from the lowest: compound 4; then compound 1; then compounds 3 and 2 (each within the scatter of the next).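

In this assay, the group on this aromatic carbon, para to a large group, matters far more than the exchanges among isopropyl, ethyl and dimethylamino suggested: trifluoromethyl in place of ethyl gives a large step (a 16-fold lower number from compound 2 to compound 4 (1.22 log units; beyond the scatter)), and trifluoromethyl in place of dimethylamino gives one of similar scale (a 14-fold lower number from compound 3 to compound 4 (1.16 log units; beyond the scatter)). The lower number is not simply a return to the level of the best earlier group, since trifluoromethyl in place of isopropyl still gives a step beyond the scatter (a 5.9-fold lower number from compound 1 to compound 4 (0.77 log units; beyond the scatter)), so compound 4 stands clearly apart from all three earlier compounds and the narrow band they formed does not describe this position. Nothing at hand accounts for the size of these steps.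

As far as these compounds go, it remains open whether this drop in the number belongs to trifluoromethyl alone or is shared by groups such as chlorine, a nitrile or trifluoromethoxy at the same place. From the compounds shown here alone, it also remains open whether the same exchange gives a step of this size on a core other than the shared one.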